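The compounds below may be only part of what the source reports. "The series", "measured", "known", "first", "only" and "open" are said of these compounds alone.

Measured so far in a functional assay (trachea) with Cavia porcellus as the target; a higher number here means a weaker inhibitor, a lower number a stronger inhibitor:
compound 1 `CC(C)n1nc(-c2cccnc2)c2ccccc2c1=O`: 3090 nM
compound 2 `C=CCn1nc(-c2cccnc2)c2ccccc2c1=O`: 2140 nM
compound 3 `O=c1c2ccccc2c(-c2cccnc2)nn1C1CCCC1`: 2750 nM

These three compounds share one core and differ only in the group on an aromatic nitrogen. Compound 3, at 2750 nM, stands level with the other two. The measured steps are a 1.1-fold lower number from compound 1 to compound 3 (0.05 log units; within the scatter) and a 1.3-fold higher number from compound 2 to compound 3 (0.11 log units; within the scatter), and the third is a 1.4-fold lower number from compound 1 to compound 2 (0.16 log units; within the scatter). All three lie within the scatter, so isopropyl, allyl and cyclopentyl cannot be told apart in this assay.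

The next compound is compound 4 `CC(=O)OCCn1nc(-c2cccnc2)c2ccccc2c1=O`, which has 2-acetoxyethyl in place of cyclopentyl on an aromatic nitrogen. The change falls at the same place as all three measured steps, which makes them the best available guide. Among the measured compounds shown here, they are only a partial guide, however, as no measured compound carries oxygen in this group. A flat result across three groups therefore points to no step beyond the scatter, but that missing test calls for a wide range. The expected change is a 1.1-fold lower number from compound 3 to compound 4 (0.04 log units; within the scatter). For compound 4 the estimated value is 2500 nM, with an expected range from 1000 nM to 6000 nM.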

Compound 4, half-maximal inhibitory concentration: 9770 nM
Compound 4: middle estimate off by 3.9-fold (0.59 log units), on the low side; measured number above the stated range.
By their numbers in this assay, from the lowest: compounds 2, 3 and 1 (each within the scatter of the next); then compound 4.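

This position is less indifferent than the three earlier groups suggested. In this assay, the step is a 3.6-fold higher number from compound 3 to compound 4 (0.55 log units; beyond the scatter) against cyclopentyl, a 4.6-fold higher number from compound 2 to compound 4 (0.66 log units; beyond the scatter) against allyl and a 3.2-fold higher number from compound 1 to compound 4 (0.50 log units; beyond the scatter) against isopropyl, so compound 4 is the weakest of the four, though only modestly so. Unlike cyclopentyl, 2-acetoxyethyl has no ring and brings 2 hydrogen-bond acceptors, and it is the only group here that contains oxygen, so a group at this position can shift the number after all. Nothing available explains why this group gives a weaker number.

The result also cannot separate the possible sources of the change, since the ester, the oxygen atoms and the open chain all enter together in one compound. A simple 2-hydroxyethyl or 2-methoxyethyl group would help to show whether the whole acetoxy ester matters or oxygen alone is enough, while a plain longer carbon chain or an amine at the end of the ethyl chain would show how far this position tolerates other kinds of group.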